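A Furan-3-yl for Thiophen-2-yl Swap Made Twice

A few compounds are considered here, and "the series" means these few. Any claim that something is new, unique, unknown or untested is made for them only; others in the source may bear on it.

Compound 1 `Cc1ncnc2c1c(-c1ccoc1)cn2[C@@H]1O[C@H](CO)[C@@H](O)[C@H]1O`: > 20000 nM
Compound 2 `Nc1nc2c(c(-c3cccs3)cn2[C@@H]2O[C@H](CO)[C@@H](O)[C@H]2O)c(=O)[nH]1`: > 20000 nM
Compound 3 `Cc1ncnc2c1c(-c1cccs1)cn2[C@@H]1O[C@H](CO)[C@@H](O)[C@H]1O`: > 15000 nM

Of the compounds shown here, three have been measured in a functional assay on HeLa S3 cells (Homo sapiens) for antiproliferative activity, read by XTT assay, with a stated time of 72 h (a higher number here means a weaker inhibitor, a lower number a stronger inhibitor), and none of them gave a number. In this assay compound 3 gives > 15000 nM, which is a limit of the assay. Compound 1 gives > 20000 nM, again a limit. For the measured compounds named here, the only change between them is furan-3-yl in place of thiophen-2-yl on an aromatic carbon, and the step that the two limits leave unreadable from compound 3 to compound 1 cannot be read in size because the limit of > 15000 nM in this assay, at which 1 of the 3 values shown sits, and the limit of > 20000 nM in this assay, at which 2 of the 3 values shown sit, are both limits rather than numbers.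

Compound 2 carries a different core from compound 3; how the two cores differ is not broken down here. In this assay compound 2 gives > 20000 nM, a limit.

Compound 4 `Nc1nc2c(c(-c3ccoc3)cn2[C@@H]2O[C@H](CO)[C@@H](O)[C@H]2O)c(=O)[nH]1` has not yet been measured. It stands to compound 2 as compound 1 stands to compound 3: the change is furan-3-yl in place of thiophen-2-yl on an aromatic carbon, and since the surroundings of the place are described in the same words for both pairs, it is the same change. The measured pair gives no readable size for it, and compound 2 itself sits at a limit, so the expectation for compound 4 rests on that limit alone. The step that the limit leaves unreadable from compound 2 to compound 4 is estimated to be small, with the measured step that the two limits leave unreadable from compound 3 to compound 1 offering no reason to expect otherwise. Compound 4 is therefore expected to give about 30000 nM in this assay, between 8000 nM and 100000 nM, most likely reported as a limit.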

Compound 4, half-maximal inhibitory concentration: 10700 nM
Compound 4: middle estimate off by 2.8-fold (0.45 log units), on the high side; measured number inside the range.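

On one core, putting furan-3-yl in place of thiophen-2-yl on an aromatic carbon gives an at least 1.8-fold lower number from compound 2 to compound 4 (0.27 log units; that floor lies within the scatter) in this assay. For the compounds shown here, this step is only a floor, with a limit at its starting end, so its true size may be greater, but the floor alone does not establish a real change, even though compound 4 is the only one of the four compounds to give a number rather than a limit. The same change on the core of compound 3 cannot be read in size, so the series neither shows that the change carries from one core to the other nor shows that it fails to, and one end of that unreadable step stands at this limit: the limit of > 15000 nM in this assay, at which 1 of the 4 values shown sits.

The compounds shown leave open how large the change really is on either core, and whether compound 1 would give a number under conditions that reach it. They also leave open whether other groups on the same aromatic carbon, such as furan-2-yl, phenyl or an aminomethyl group, would follow compound 4 on its core, and whether they would do the same on the core of compound 3.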